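Removing a methoxy group from a weak binder

The source may report more compounds than this note shows. Statements on the series, on what has been measured and on what is new or still open speak of the compounds shown alone.

Compound 1 `Fc1ccc(-c2n[nH]cc2N2CCCNCC2)cc1`: > 10000 nM
Compound 2 `COc1ccccc1-c1n[nH]cc1N1CCNCC1`: > 10000 nM

In an assay on isolated protein for binding affinity to 5-hydroxytryptamine receptor 4 (Homo sapiens) (a higher number here means a weaker inhibitor, a lower number a stronger inhibitor), compound 1 reaches only the limit > 10000 nM. Compound 2 likewise gives only the limit > 10000 nM in this assay. Compound 2 thus stands at the limit, where every value shown sits (the limit of > 10000 nM in this assay, at which 2 of the 2 values shown sit). Compound 3 `c1ccc(-c2n[nH]cc2N2CCNCC2)cc1` differs from compound 2 by hydrogen in place of methoxy on an aromatic carbon. Within the data shown here, no step between measured compounds is available, and no step beyond the scatter in either direction is expected in this assay. Compound 3 is therefore expected at 15000 nM, between 3000 nM and 60000 nM, which is estimated to mean a step that the limit leaves unreadable from compound 2 to compound 3.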

Compound 3, inhibition constant: > 10000 nM
Compound 3 gave a limit, no number (the forecaster's own chance of this, stated with the estimate: 75%); the middle value lies beyond the limit too.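

Compound 2 and compound 3 both give only a limit, so no step can be read between them. The compounds shown leave open what effect hydrogen in place of methoxy has in this assay, where none of the three yields a number.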